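The compounds below may be only part of what the source reports. "The series", "measured", "known", "first", "only" and "open" are said of these compounds alone.

Of the compounds shown here, three sharing one core have been tested in a functional assay on the whole organism for inhibition, with Lepidium sativum as the target, tested at 1 ppm; a lower number here means less inhibition of growth, a higher number more inhibition of growth at the concentration tested. Compound 1 `CCOC(=O)C(C)CN1C(=O)c2ccccc2C1=O` gives 0%, compound 2 `COC(=O)C(C)ON1C(=O)c2ccccc2C1=O` gives 64%, and compound 3 `CCOC(=O)C(Cc1ccccc1)ON1C(=O)c2ccccc2C1=O` gives 0%. Compound 2 therefore stands highest of the three numbers; compound 1 and compound 3 each lie far lower, beyond the scatter. No two of these measured compounds differ in one place only, so no single step can be read off among them. Compound 4 `CCC(C)OC(=O)C(C)ON1C(=O)c2ccccc2C1=O` is not yet measured and differs from compound 2 in one place: sec-butyl in place of methyl on an oxygen next to a carbonyl group. Going by the values given here, with no comparable step available, a downward step of moderate size is expected, and the expected step reads a number 29 percentage points lower from compound 2 to compound 4 (beyond the scatter). Compound 4 is estimated to give 35%, with a range from 5% to 70%.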

Compound 4, percent growth inhibition at one concentration: 42%
Beside the measured number, compound 4's estimate is 7 percentage points below it; measured number inside the range.
By their numbers in this assay, from the lowest: compounds 1 and 3 (each within the scatter of the next); then compound 4; then compound 2.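

In this assay, the place on an oxygen next to a carbonyl group accepts a larger group without losing all activity: sec-butyl in place of methyl gives a number 22 percentage points lower from compound 2 to compound 4 (beyond the scatter), a modest but real fall. Even so, compound 4 still inhibits growth, at 42% in this assay. Nothing available explains the size of this step.

Going by these compounds, whether an ethyl or a straight butyl chain at this oxygen would stay nearer compound 2 or compound 4 remains open. So does the outcome of replacing the ester with a carboxylic acid.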